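The compounds below may be only part of what the source reports. "The series", "measured", "known", "first", "only" and "open" are said of these compounds alone.

For the measured compounds named here, compound 3 `Cc1noc(NS(=O)(=O)c2ccc(NC(=O)Nc3ccccc3)cc2)c1C` gives 38000 nM in an assay on VSM-A10 cells for antagonist activity at Endothelin-1 receptor (Rattus norvegicus) (on this read-out lower numbers stand for stronger inhibition and higher numbers for weaker inhibition), the highest of the three numbers so far; compound 1 `Cc1noc(NS(=O)(=O)c2ccc(NCc3ccccc3)cc2)c1C` gives 9800 nM and compound 2 `Cc1noc(NS(=O)(=O)c2ccc(F)cc2)c1C` gives 1000 nM. Compound 4 `Cc1noc(NS(=O)(=O)c2ccc(NC(=O)CN)cc2)c1C` differs from compound 3 by aminomethyl in place of anilino on a carbonyl carbon. Going by the values given here, no measured step matches this change directly. The step of a 3.9-fold higher number from compound 1 to compound 3 (0.59 log units; beyond the scatter) shows that adding phenylcarbamoyl weakened inhibition, and the step of a 9.8-fold lower number from compound 1 to compound 2 (0.99 log units; beyond the scatter) shows that a smaller group in the same region strengthened it. Removing the anilino ring from compound 3 is therefore expected to move the number back toward compound 1, a modest expected step of a 2.5-fold lower number from compound 3 to compound 4 (0.40 log units; beyond the scatter). For compound 4 the estimate in this assay is 15000 nM, within 4000 nM to 60000 nM.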

Compound 4, half-maximal inhibitory concentration: 6500 nM
For compound 4 the middle estimate is 2.3-fold (0.36 log units) above the measured one, and the stated range covers the measured number.
By their numbers in this assay, from the lowest: compound 2; then compounds 4 and 1 (each within the scatter of the next); then compound 3.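

In this assay aminomethyl in place of anilino on a carbonyl carbon gives a 5.8-fold lower number from compound 3 to compound 4 (0.77 log units; beyond the scatter) and so the loss seen with phenylcarbamoyl does not come with every carbonyl group on this nitrogen. With a 1.5-fold lower number from compound 1 to compound 4 (0.18 log units; within the scatter) (aminomethyl)carbonyl and benzyl cannot be told apart, while a 6.5-fold higher number from compound 2 to compound 4 (0.81 log units; beyond the scatter) leaves the fluoro compound clearly ahead. No measurement here explains these shifts.

Still open, as far as these compounds go, is what the amine itself contributes. A plain methyl, a longer chain ending in an amine, or a carboxylic acid on that carbonyl carbon could separate the part played by the amine from that of the chain.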